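This account rests on a few compounds, and the source may have more. Where it says the series, first, only, none or still open, it means among the compounds named here.

Compound 1 `COC(=O)/C=C/c1cccc(N(Cc2ccc(-c3cccc(Cl)c3)cc2)C(=O)C2CCCCC2)c1` gives 94 nM in an assay on isolated protein with Bile acid receptor (Homo sapiens) as the target; a lower number here means that less compound is needed, a higher number that more compound is needed for the effect. Compound 2 `COC(=O)/C=C/c1cccc(N(Cc2ccc(-c3cccc(C)c3)cc2)C(=O)C2CCCCC2)c1` gives 109 nM in this assay, and the step of a 1.2-fold higher number from compound 1 to compound 2 (0.06 log units; within the scatter). Compound 3 `CCOC(=O)/C=C/c1ccc(CN(C(=O)C2CCCCC2)c2cccc(/C=C/C(=O)OC)c2)cc1` reaches only the limit of this assay, giving > 1000 nM. Compound 3 therefore stands at the weak end of the three compounds shown, sitting at the limit of > 1000 nM in this assay, at which 1 of the 3 values shown sits. The steps of an at least 10-fold higher number from compound 1 to compound 3 (1.02 log units; beyond the scatter) and an at least 9.1-fold higher number from compound 2 to compound 3 (0.96 log units; beyond the scatter) both run toward that limit. Compound 4 `COC(=O)/C=C/c1cccc(N(Cc2ccc(/C=C/C(=O)OCc3ccccc3)cc2)C(=O)C2CCCCC2)c1` differs from compound 3 by phenyl in place of methyl on a saturated chain carbon bound to an oxygen next to a carbonyl group. Neither measured step touches the ester group, so the direction of this change has no direct guide among the measured compounds. Compound 4 is expected to remain near the limit, with the step that the limit leaves unreadable from compound 3 to compound 4 estimated to fall within the scatter. In this assay compound 4 is estimated at 1500 nM, with a range from 400 nM to 6000 nM.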

Compound 4, half-maximal effective concentration: > 1000 nM
Compound 4 gave a limit, no number (the forecaster's own chance of this, stated with the estimate: 60%); the middle value is on the limit's open side.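

In this assay compound 4 also gives only a limit, so moving from ethoxycarbonyl to benzyloxycarbonyl leaves this position at the limit: the limit of > 1000 nM in this assay, at which 2 of the 4 values shown sit. The steps of an at least 9.1-fold higher number from compound 2 to compound 4 (0.96 log units; beyond the scatter) and an at least 10-fold higher number from compound 1 to compound 4 (1.02 log units; beyond the scatter) show that a 2-(benzyloxycarbonyl)ethenyl group, like the ethoxycarbonyl version, does not match the 3-chlorophenyl or 3-methylphenyl groups at this place. The step between compound 3 and compound 4 cannot be read. Still open, on these data alone, is whether a carboxylic acid or an amine in place of the benzyloxycarbonyl group would give a value inside the range of this assay.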